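This account rests on a few compounds, and the source may have more. Where it says the series, first, only, none or still open, it means among the compounds named here.

In a functional assay on MDA-MB-231 cells (Homo sapiens) for antiproliferative activity, read by MTT assay (on this read-out lower numbers stand for stronger inhibition and higher numbers for weaker inhibition), compound 2 `CC/C=C\C/C=C\C/C=C\CCCCCCCc1cc(=O)c2c(O)cc(O)cc2o1` gives 6790 nM and compound 3 `CC/C=C\C/C=C\C/C=C\CCCCCCCc1cc(=O)c2c(O)cc(OCOC)cc2o1` gives 6790 nM, level at the digits shown. Compound 1 `CCCC/C=C\CCCCCCCCCc1cc(=O)c2c(O)cc(OCOC)cc2o1` reports > 87000 nM, which is a limit of the assay and not a number. Compound 4 `CC/C=C\C/C=C\C/C=C\CCCCCCCc1cc(=O)c2c(O)c(C)c(OCOC)cc2o1` differs from compound 3 by methyl in place of hydrogen on an aromatic carbon, ortho to a hydroxy group and ortho to a methoxymethoxy group (methyl in place of hydrogen on an aromatic carbon). Among the compounds with values here, no measured step touches this carbon. The large chain step, an at least 12-fold lower number from compound 1 to compound 3 (1.10 log units; beyond the scatter), lies elsewhere in the molecule, and methoxymethyl in place of hydrogen on an oxygen, no change at the digits printed from compound 2 to compound 3 (within the scatter), made no difference. A change within the scatter, in neither direction, is therefore expected in this assay. The expected step is a 1.0-fold lower number from compound 3 to compound 4 (0.02 log units; within the scatter). Compound 4 is estimated at 6500 nM, with an expected range of 2200 nM to 20000 nM.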

Compound 4, half-maximal inhibitory concentration: 6790 nM
Estimate against measurement, compound 4: 1.0-fold (0.02 log units) below, within the range that was stated.
By their numbers in this assay, from the lowest: compounds 2, 3 and 4 (each within the scatter of the next). At a limit, above all of these: compound 1.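

In this assay, methyl in place of hydrogen on this aromatic carbon, ortho to a hydroxy group and ortho to a methoxymethoxy group, gives no change at the digits printed from compound 3 to compound 4 (within the scatter). Within the data shown here, the earlier compounds all carry hydrogen here, so this is the first reading at this carbon, and it shows that the single added methyl leaves the number where it stood. Nothing in the data shown gives a reason for this. On these data alone, whether an amine or a carboxylic acid on this carbon would read the same remains open. So does whether methyl here would read the same on the chain of compound 1.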